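Working notes: methyl step from compound 3 to compound 4

The compounds below may be only part of what the source reports. "The series", "measured", "known", "first", "only" and "open" are said of these compounds alone.

Measured compounds
- compound 1, `O=C(Nc1cccc(Nc2ccc([N+](=O)[O-])c3ncnc(O)c23)c1)c1ccccc1`: no result reported
- compound 2, `O=C(Nc1cccc(Nc2ccc([N+](=O)[O-])c3ncnc(O)c23)c1)c1ccccc1F`: no result reported
- compound 3, `O=C(Nc1ccc(Nc2ccc([N+](=O)[O-])c3ncnc(O)c23)cc1)c1ccccc1`: see value below

Among the measured compounds shown here, only one number exists in this set. In an ADME assay on L02 cells (Homo sapiens) for cytotoxicity (on this read-out lower numbers stand for stronger inhibition and higher numbers for weaker inhibition), compound 3 gives 65300 nM. In this assay, for the measured compounds named here, compound 1 gives "not determined" (no result reported) and compound 2 gives "not determined" (no result reported), so compound 3 stands alone: it is neither the strongest nor the weakest of anything, simply the only compound with a number, and no step between measured compounds can be read off.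

Compound 4, `Cc1ccc(C(=O)Nc2ccc(Nc3ccc([N+](=O)[O-])c4ncnc(O)c34)cc2)cc1`, differs from compound 3 by methyl in place of hydrogen on an aromatic carbon. Going by the values given here, no measured pair shows what such a change does in this assay, so the expectation rests on the single value of compound 3 alone. The step of a 1.1-fold lower number from compound 3 to compound 4 (0.04 log units; within the scatter) is expected to stay within the usual scatter of this assay, with no preferred direction. Compound 4 is therefore expected to give 60000 nM in this assay, with a range from 25000 nM to 150000 nM.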

Compound 4, half-maximal inhibitory concentration: 93200 nM
The estimate for compound 4 lay 1.6-fold (0.19 log units) below the measured number; low and high end bracket the measured number.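

In this assay, among the compounds shown here, the first readable step is methyl in place of hydrogen on an aromatic carbon, para to a large group, which gives a 1.4-fold higher number from compound 3 to compound 4 (0.15 log units; within the scatter). Phenyl to 4-methylphenyl at this place therefore stays within the scatter, a reading that rests on this single pair, and steps involving compound 1 and compound 2 cannot be read. No measurement shown here bears on the reason for this result.

Open, as far as these compounds go, is whether a different group at this place, such as an amine, a carboxylic acid or a longer chain, would give a step beyond the scatter from compound 3. Also open, from the compounds shown here alone, is whether methyl on another carbon of this ring would stay within the scatter.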